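The source may report more compounds than this note shows. Statements on the series, on what has been measured and on what is new or still open speak of the compounds shown alone.

Of the compounds shown here, two have been measured in an ADME assay on the whole organism for metabolic stability, with Rattus norvegicus as the target, at a dose of 3 mg/kg by the oral route; on this read-out higher numbers stand for a longer-lived compound and lower numbers for a shorter-lived compound. Compound 1 `COC(=O)N[C@H](C(=O)N1CCC[C@H]1C(=O)Nc1ccc([C@@H]2CC[C@@H](c3ccc(NC(=O)[C@@H]4CCCN4C(=O)[C@@H](NC(=O)OC)C(C)C)cc3)N2c2ccc(F)cc2)cc1)C(C)C` gives 3 h. Compound 2 `COC(=O)N[C@H](C(=O)N1CCC[C@H]1C(=O)Nc1ccc([C@@H]2CC[C@@H](c3ccc(NC(=O)[C@@H]4CCCN4C(=O)[C@@H](NC(=O)OC)[C@H]4CCOC4)cc3)N2c2ccc(F)cc2)cc1)[C@H]1CCOC1` gives 0.6 h in this assay, the lower of the two numbers, and the gap between compound 2 and compound 1 is beyond the scatter of the assay, so compound 2 is the shorter-lived of the pair.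

Compound 3 `COC(=O)N[C@H](C(=O)N1CCC[C@H]1C(=O)Nc1ccc([C@H]2CC[C@H](c3ccc(NC(=O)[C@@H]4CCCN4C(=O)[C@@H](NC(=O)OC)[C@H]4CCOC4)cc3)N2c2ccc(F)cc2)cc1)[C@H]1CCOC1` has not yet been measured. It differs from compound 2 as follows: the two compounds have the same atoms and bonds and differ only in configuration as drawn: 2 of 8 stereo elements differ; a stereocentre at a saturated ring carbon is drawn S in compound 2 and R in compound 3; a stereocentre at a saturated ring carbon is drawn S in compound 2 and R in compound 3. Among the compounds with values here, no measured pair in this set separates two compounds by a change in configuration alone, so there is no step to lean on. With the same atoms and bonds and only the drawn configuration changed, the half-life in this assay is expected to stay close to that of compound 2, with the step of no change at the digits printed from compound 2 to compound 3 (within the scatter) estimated to lie within the scatter. Compound 3 is therefore expected to give about 0.6 h, in the range 0.3 h to 1.3 h.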

Compound 3, half-life: 0.5 h
The estimate for compound 3 lay 1.2-fold (0.08 log units) above the measured number; measured number inside the range.
By their numbers in this assay, from the lowest: compounds 3 and 2 (each within the scatter of the next); then compound 1.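

Within the data shown here, this pair gives the first reading of configuration alone, and the reading is clean, since nothing else in the structures could contribute: the fact that compounds 2 and 3 differ only in the configuration as drawn. Redrawing both stereocentres at saturated ring carbons from S to R gives a 1.2-fold lower number from compound 2 to compound 3 (0.08 log units; within the scatter) in this assay. For this pair, then, the half-life does not separate the two drawn configurations, though one pair says nothing about the series as a whole.

The compounds shown leave open what either stereocentre does when redrawn alone, as both differ together here. They also leave open whether configuration would count for as little with a chlorine or a tert-butyl group in place of the fluorine.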